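From 4-Methylphenyl to Cyclohexyl on the Amide Nitrogen

A few compounds are considered here, and "the series" means these few. Any claim that something is new, unique, unknown or untested is made for them only; others in the source may bear on it.

Measured compounds:
compound 1 `COc1ccc(OC)c(CN(C(=O)Nc2ccc(C)cc2)n2cnnc2)c1`: 20900 nM
compound 2 `COc1ccc(CN(C(=O)Nc2ccc(Cl)c(C(F)(F)F)c2)n2cnnc2)cc1OC`: a limit of the assay, > 50000 nM
compound 3 `Cc1ccsc1CN(C(=O)Nc1ccc(Cl)c(C(F)(F)F)c1)n1cnnc1`: 24100 nM

In a functional assay on DU-145 cells (Homo sapiens) for cytotoxicity, read by MTT assay, with a stated time of 48 h (on this read-out higher numbers stand for weaker inhibition and lower numbers for stronger inhibition), compound 1 gives 20900 nM, the lowest of the two actual numbers; compound 3 lies close by, within the usual scatter. For compound 2 only a limit is recorded, (the limit of > 50000 nM in this assay, at which 1 of the 3 values shown sits). Among the compounds with values here, the single measured step, an at least 2.0-fold lower number from compound 2 to compound 3 (0.31 log units; beyond the scatter), changes the group on the saturated chain carbon, not the amide nitrogen. Compound 4 `COc1ccc(OC)c(CN(C(=O)NC2CCCCC2)n2cnnc2)c1` differs from compound 1 in one place: cyclohexyl in place of 4-methylphenyl on an amide-type nitrogen. Within the data shown here, no measured step touches this part of the structure, so there is no basis to expect a shift beyond the scatter in this assay. Compound 4 is therefore expected to give about 25000 nM, estimated between 10000 nM and 60000 nM, meaning an expected step of a 1.2-fold higher number from compound 1 to compound 4 (0.08 log units; within the scatter).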

Compound 4, half-maximal inhibitory concentration: 29800 nM
Beside the measured number, compound 4's estimate is 1.2-fold (0.08 log units) below it; the measured number falls inside the stated range.
By their numbers in this assay, from the lowest: compounds 1, 3 and 4 (each within the scatter of the next). At a limit, above all of these: compound 2.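

This is the only step shown on the amide-type nitrogen: in this assay, cyclohexyl in place of 4-methylphenyl gives a 1.4-fold higher number from compound 1 to compound 4 (0.15 log units; within the scatter). In this pair, then, an aromatic carbon ring and a non-aromatic one on this nitrogen cannot be told apart by the read-out. Nothing measured here explains why the two groups read alike. Still open, as far as these compounds go, is whether a group of a different kind at this place, such as a carboxylic acid, an amine or a short ethyl chain, would move the number beyond the scatter.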